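Changing the group on the ring amine nitrogen

This account rests on a few compounds, and the source may have more. Where it says the series, first, only, none or still open, it means among the compounds named here.

Measured so far:
compound 1 `COc1ccc(N2CCN(C(=S)SCc3ccc(C(=O)Nc4ccccc4N)cc3)CC2)cc1` gives 52.3%
compound 2 `Nc1ccccc1NC(=O)c1ccc(CSC(=S)N2CCN(Cc3cccnc3)CC2)cc1` gives 78%

In a functional assay on HeLa cells (Homo sapiens) for antiproliferative activity, read by CCK-8 assay, with a stated time of 72 h, tested at 8 uM (on this read-out higher numbers stand for a stronger effect at the one concentration tested and lower numbers for a weaker effect), compound 2 stands highest of the two numbers; its nearest neighbour is compound 1, and the step of a number 25.7 percentage points higher from compound 1 to compound 2 (beyond the scatter) lies beyond the scatter. Compound 3 `Nc1ccccc1NC(=O)c1ccc(CSC(=S)N2CCN(c3cnccn3)CC2)cc1` has not yet been measured. It differs from compound 2 by pyrazin-2-yl in place of (pyridin-3-yl)methyl on an amine nitrogen in a ring. Among the compounds with values here, the one measured step that bears on this is a number 25.7 percentage points higher from compound 1 to compound 2 (beyond the scatter), where a group attached directly through its aromatic ring to the ring nitrogen gave way to one attached through a methylene. Within the data shown here, compound 3 returns to a ring attached directly, though now with two hetero atoms rather than the methoxy-bearing ring of compound 1, so a modest fall from compound 2 is expected, a number 18 percentage points lower from compound 2 to compound 3 (beyond the scatter), smaller than the one measured step and uncertain in size. Compound 3 is therefore estimated at 60%, within a range of 42% to 78%.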

Compound 3, a percentage reported as inhibition, at one concentration (the size of the read-out at that concentration, not a potency): 76.9%
The estimate for compound 3 lay 16.9 percentage points below the measured number; low and high end bracket the measured number.
By their numbers in this assay, from the lowest: compound 1; then compounds 3 and 2 (each within the scatter of the next).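

In this assay, the replacement of (pyridin-3-yl)methyl by pyrazin-2-yl gives a number 1.1 percentage points lower from compound 2 to compound 3 (within the scatter), so at this ring nitrogen a ring attached directly serves as well as one attached through a methylene. The step of a number 24.6 percentage points higher from compound 1 to compound 3 (beyond the scatter) shows that direct attachment does not by itself bring the lower number of compound 1: compound 1 and compound 3 both carry a directly attached ring, and they part at the choice of that ring. Nothing measured here accounts for this outcome.

The compounds shown leave open whether an unsubstituted phenyl or a 4-methoxybenzyl group on this nitrogen would stand with compound 1 or with compound 3. They also leave open what a group without a ring, such as an acetyl or a short alkyl chain, would give.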